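Benzoyl on the side-chain amine of compound 1

A few compounds are considered here, and "the series" means these few. Any claim that something is new, unique, unknown or untested is made for them only; others in the source may bear on it.

Compound 1 (`NCCCNc1c(C(=O)NCc2ccc(F)cc2)nc(Br)c2cccnc12`) has no single number in a functional assay on SK-BR-3 cells (Homo sapiens) for cytotoxicity, read by MTT assay, with a stated time of 72 h (on this read-out lower numbers stand for stronger inhibition and higher numbers for weaker inhibition), and its entry reads ("not determined" (no result reported)) so it gives no measured starting point. Within the data shown here, on the same core, compound 2 (`Nc1ccc(Nc2c(C(=O)NCc3ccc(F)cc3)nc(Br)c3cccnc23)cc1`) gives 4000 nM as the only number. Compound 3 (`O=C(NCCCNc1c(C(=O)NCc2ccc(F)cc2)nc(Br)c2cccnc12)c1ccccc1`) is still unmeasured. The change benzoyl in place of hydrogen on an amine nitrogen puts benzoyl in place of hydrogen on an amine nitrogen. In this assay the only measured level is that of compound 2 (4000 nM) and no firm direction can be given. For compound 3 the estimated value is 3000 nM with an expected range from 800 nM to 11000 nM in this read-out.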

Compound 3, half-maximal inhibitory concentration: 1000 nM
Compound 3: the middle estimate sits 3.0-fold (0.48 log units) above what was measured; measured number inside the range.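

No step can be read from compound 1 to compound 3: in this assay compound 3 gives 1000 nM while compound 1 has no single number. The compounds shown leave open what benzoyl in place of hydrogen on the amine nitrogen does to this read-out. No evidence bears on the result.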